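The source may report more compounds than this note shows. Statements on the series, on what has been measured and on what is new or still open speak of the compounds shown alone.

In a functional assay on SAOS-2 cells (Homo sapiens) for antiproliferative activity, read by MTT assay, with a stated time of 72 h (on this read-out lower numbers stand for stronger inhibition and higher numbers for weaker inhibition), compound 2, with the structure `CCCCCOC1=C(C(=O)c2ccccc2)C(c2ccc(Br)cc2)N(CCCn2ccnc2)C1=O`, gives 9990 nM, the lowest number among the three compounds measured, and its gaps to both neighbours lie beyond the scatter. Compound 1, `O=C(C1=C(O)C(=O)N(CCCn2ccnc2)C1c1ccc(Br)cc1)c1ccccc1`, gives 31600 nM in this assay, and compound 3, `Cc1ccc(NC2=C(C(=O)c3ccccc3)C(c3ccc(Br)cc3)N(CCCn3ccnc3)C2=O)cc1`, gives 31900 nM. The step from compound 1 to compound 2 shows a 3.2-fold lower number from compound 1 to compound 2 (0.50 log units; beyond the scatter), while the step from compound 1 to compound 3 shows a 1.0-fold higher number from compound 1 to compound 3 (0.00 log units; within the scatter), and that from compound 2 to compound 3 shows a 3.2-fold higher number from compound 2 to compound 3 (0.50 log units; beyond the scatter).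

Compound 4, `O=C(C1=C(Nc2ccc(I)cc2)C(=O)N(CCCn2ccnc2)C1c1ccc(Br)cc1)c1ccccc1`, has not yet been measured. It differs from compound 2 by the change ((4-iodophenyl)amino in place of pentyloxy on a double-bonded ring carbon), that is, a (4-iodophenyl)amino group in place of pentyloxy on a double-bonded ring carbon of the shared core. For the measured compounds named here, the step that bears most directly on this change is the one from compound 2 to compound 3, which also replaced pentyloxy with an arylamino group and gave a higher number; the only difference between compound 3 and compound 4 is the iodine in place of the methyl on the phenyl ring, for which no measured step exists. Compound 4 is therefore expected to show a 3.0-fold higher number from compound 2 to compound 4 (0.48 log units; beyond the scatter), a step of similar size to that seen for compound 3. The estimate for compound 4 in this assay is 30000 nM, with a range from 10000 nM to 90000 nM.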

Compound 4, half-maximal inhibitory concentration: 23400 nM
For compound 4 the middle estimate is 1.3-fold (0.11 log units) above the measured one; measured number inside the range.
By their numbers in this assay, from the lowest: compound 2; then compounds 4, 1 and 3 (each within the scatter of the next).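

In this assay, a second arylamino group on this double-bonded ring carbon also fails to match pentyloxy, with a 2.3-fold higher number from compound 2 to compound 4 (0.37 log units; beyond the scatter), so compound 2 now stands apart from two arylamino compounds rather than one. The group on the aromatic ring of the arylamino substituent makes no difference that can be read here: iodo in place of methyl gives a 1.4-fold lower number from compound 3 to compound 4 (0.13 log units; within the scatter), and (4-iodophenyl)amino in place of hydroxy gives a 1.4-fold lower number from compound 1 to compound 4 (0.13 log units; within the scatter), so hydroxy and both arylamino groups cannot be told apart at this position. The data offer no evidence on why pentyloxy differs from these three groups.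

From the compounds shown here alone, it remains open whether the difference follows the oxygen link or the five-carbon chain, a question that a pentylamino group in the same place would address. Also open, going by these compounds, is how the number responds to the length and shape of the chain, as with a propyloxy, an octyloxy or a benzyloxy group, given that compound 2 itself reaches only 9990 nM.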